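This account rests on a few compounds, and the source may have more. Where it says the series, first, only, none or still open, it means among the compounds named here.

Cytotoxicity is followed in a toxicity assay on NIH3T3 cells (Mus musculus) for cytotoxicity, read by resazurin assay; on this read-out lower numbers stand for an effect already at smaller amounts and higher numbers for an effect only at larger amounts of compound. Compound 3 `N#Cc1ccc(NCc2cncn2Cc2ccc(-c3ccccc3)cc2)cc1-c1ccccc1` carries a cyano group on the core; in this assay compound 3 stops at > 1000 nM, which is a limit and not a number, as recorded in the limit of > 1000 nM in this assay, at which 1 of the 3 values shown sits. Compound 1 `c1ccc(-c2ccc(Cn3cncc3CNc3ccc(-c4onc5ccccc45)c(-c4ccccc4)c3)cc2)cc1` in this assay gives > 10000 nM, likewise a limit. Compound 2 `c1ccc(-c2ccc(Cn3cncc3CNc3ccc(-c4ccc[nH]4)c(-c4ccccc4)c3)cc2)cc1` in this assay also ends at the limit > 10000 nM. Both of these sit at the limit of > 10000 nM in this assay, at which 2 of the 3 values shown sit. The steps a step that the two limits leave unreadable from compound 1 to compound 2, a step that the two limits leave unreadable from compound 1 to compound 3 and a step that the two limits leave unreadable from compound 2 to compound 3 are accordingly all unreadable in size. Compound 4 `c1ccc(-c2ccc(Cn3cncc3CNc3ccc(-c4nc5ccccc5o4)c(-c4ccccc4)c3)cc2)cc1` differs from compound 3 by 1,3-benzoxazol-2-yl in place of cyano on an aromatic carbon. Among the compounds with values here, no measured step gives a size to build on. Compound 4 is therefore expected to give 20000 nM in this assay, within 8000 nM to 60000 nM, most probably again as a limit. The step that the limit leaves unreadable from compound 3 to compound 4 is expected to be none beyond the scatter.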

Compound 4, half-maximal effective concentration: > 10000 nM
Compound 4: only a limit was reported (the forecaster's own chance of this, stated with the estimate: 85%); the middle value does not contradict the limit.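

Compound 4 gives > 10000 nM, a limit, and its steps to compound 1, compound 2 and compound 3 cannot be read. The compounds shown leave open where the half-maximal effective concentration of any of them lies in this assay.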